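This account rests on a few compounds, and the source may have more. Where it says the series, first, only, none or still open, it means among the compounds named here.

Among the measured compounds shown here, in a functional assay on A549 cells (Homo sapiens) for cytotoxicity, read by MTT assay, with a stated time of 72 h (on this read-out higher numbers stand for weaker inhibition and lower numbers for stronger inhibition), compound 3 `COC(=O)c1sc2ccccc2c1Nc1cc(OC)c(OC)c(OC)c1` gives 2850 nM, the second highest of the three numbers so far. Compound 1 `CCOC(=O)c1sc2ccccc2c1Nc1cc(OC)c(OC)c(OC)c1` gives 8530 nM, and compound 2 `COC(=O)c1sc2cc(C)ccc2c1Nc1cc(OC)c(OC)c(OC)c1` gives 10.8 nM. Compound 4 `COC(=O)c1sc2ccc(C)cc2c1Nc1cc(OC)c(OC)c(OC)c1` differs from compound 3 by one change: methyl in place of hydrogen on an aromatic carbon. The closest guide is the same kind of swap on another aromatic carbon, seen in reverse as a 260-fold higher number from compound 2 to compound 3 (2.42 log units; beyond the scatter), a large step. The methyl stands on a different carbon in compound 4, so only part of that step is expected to carry over. The modest ester change, a 3.0-fold lower number from compound 1 to compound 3 (0.48 log units; beyond the scatter), lies elsewhere in the molecule and says little here. The expected change is a 9.5-fold lower number from compound 3 to compound 4 (0.98 log units; beyond the scatter), a lower number. For compound 4 the estimate is 300 nM, with a range from 30 nM to 3000 nM.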

Compound 4, half-maximal inhibitory concentration: 2810 nM
The estimate for compound 4 lay 9.4-fold (0.97 log units) below the measured number; the range from low to high includes it.
By their numbers in this assay, from the lowest: compound 2; then compounds 4 and 3 (each within the scatter of the next); then compound 1.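

In this assay, methyl in place of hydrogen on this aromatic carbon gives a 1.0-fold lower number from compound 3 to compound 4 (0.01 log units; within the scatter), so at this position the swap has no effect beyond the scatter. The same swap on another aromatic carbon, read in reverse, gives a 260-fold higher number from compound 2 to compound 3 (2.42 log units; beyond the scatter), so what a methyl does here depends on which carbon carries it. Nothing measured here explains that contrast. On these data alone, it remains open whether a longer chain such as ethyl, or an amine, on this same carbon would also leave the number within the scatter.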